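The compounds below may be only part of what the source reports. "The series", "measured", "known", "first", "only" and "open" are said of these compounds alone.

Three compounds of this series carry a measurement in a physicochemical assay for lipophilicity; on this read-out lower numbers stand for lower lipophilicity and higher numbers for higher lipophilicity. Compound 1, `CNC(=O)c1cc(C(=O)N[C@H]2CC[C@H](O)CC2)c([C@@H](C)c2cccc(C)c2)o1`, gives 3.3 in this assay. Compound 2, `CC[C@@H](c1ccccc1)n1nc(C(=O)NC)cc1C(=O)N[C@H]1[C@@H]2C[C@H](O)C[C@@H]21`, gives 3.6. Compound 3, `CNC(=O)c1cc(C(=O)N[C@H]2CC[C@H](OC)CC2)c([C@@H](C)c2ccccc2)o1`, gives 4.1, the highest of the three numbers; the gap to compound 2 and the wider gap to compound 1 both lie beyond the usual scatter of such measurements.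

The account now follows a single change made to compound 3. Compound 4, `CNC(=O)c1cc(C(=O)N[C@H]2CC[C@H](O)CC2)c([C@@H](C)c2ccccc2)o1`, has not yet been measured in this assay. Compared with compound 3 it differs in one place: hydrogen in place of methyl on an oxygen on a saturated carbon. In the names of the groups, methoxy becomes hydroxy, and the 4-methoxycyclohexyl group becomes a 4-hydroxycyclohexyl group.

Among the compounds with values here, no measured pair in this set shows this same change on its own, so the expected step has to be judged from the compounds at hand. Compound 1, which carries a hydroxy on its ring, stands well below compound 3, which carries the methoxy, although the two also differ elsewhere. The step from compound 3 to compound 4 is expected to be a drop of a number 0.90 log units lower from compound 3 to compound 4 (beyond the scatter), clearly beyond the scatter. Compound 4 is therefore estimated at 3.2, with a likely range from 2.7 to 3.7.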

Compound 4, distribution coefficient: 2.8
Beside the measured number, compound 4's estimate is 0.40 log units above it; the range from low to high includes it.
By their numbers in this assay, from the lowest: compound 4; then compounds 1 and 2 (each within the scatter of the next); then compound 3.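

In this assay, within the data shown here, hydrogen in place of methyl on an oxygen on a saturated carbon gives a number 1.30 log units lower from compound 3 to compound 4 (beyond the scatter) and is a large step, so turning the 4-methoxycyclohexyl group into a 4-hydroxycyclohexyl group now has a size measured on its own, which the earlier compounds, differing in more than one place, could not provide. Compound 4 also opens a second single-place comparison, in which hydrogen in place of methyl on an aromatic carbon gives a number 0.50 log units lower from compound 1 to compound 4 (beyond the scatter) and is a modest step, so both changes are now seen on the same shared core and both lower the number. No measurement shown here accounts for the size of either step.

The compounds shown leave open whether methoxy to hydroxy would give a step of similar size on the core of compound 2, and whether the two changes would simply add if made together. They also leave open where the number would fall with an amine, a carboxylic acid or a longer chain such as ethoxy in place of the hydroxy on the 4-hydroxycyclohexyl group.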